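The source may report more compounds than this note shows. Statements on the series, on what has been measured and on what is new or still open speak of the compounds shown alone.

Compound 2 `CC(C)[C@H](NC(=O)CCN(C)C)c1cccc(F)c1N1CCN(C(=O)[C@@H]2CN(C(C)C)C[C@H]2c2cccc(F)c2)CC1` gives 560 nM in an assay on HEK293 cells for displacement of a labelled ligand from Melanocortin receptor 4 (Homo sapiens); on this read-out higher numbers stand for weaker inhibition and lower numbers for stronger inhibition. Of the two compounds measured, it and compound 1 `Cc1cccc([C@@H]2CN(C(C)C)C[C@H]2C(=O)N2CCN(c3c(F)cccc3[C@@H](NC(=O)CCN(C)C)C(C)C)CC2)c1`, which gives 470 nM in this assay, lie within the scatter of each other, the step being a 1.2-fold higher number from compound 1 to compound 2 (0.08 log units; within the scatter), a fluoro in place of a methyl on an aromatic carbon. Compound 3 `CC(C)[C@H](NC(=O)CCN(C)C)c1cccc(F)c1N1CCN(C(=O)[C@@H]2CN(C(C)C)C[C@H]2c2cc(F)cc(F)c2)CC1` differs from compound 2 by fluoro in place of hydrogen on an aromatic carbon. For the measured compounds named here, only the step from compound 1 to compound 2 bears on this change, and it does so loosely: that step exchanged one group for another on the ring that carries the change rather than taking 3-fluorophenyl to 3,5-difluorophenyl, and it stayed within the scatter, so no direction can be read from it. The expected step from compound 2 to compound 3 is therefore small, no change at the digits printed from compound 2 to compound 3 (within the scatter). Compound 3 is estimated at 560 nM, with a range from 250 nM to 1300 nM.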

Compound 3, inhibition constant: 7800 nM
Compound 3: the middle estimate sits 14-fold (1.14 log units) below what was measured; measured number outside the range, above it.
By their numbers in this assay, from the lowest: compounds 1 and 2 (each within the scatter of the next); then compound 3.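

In this assay, the position meta to the fluoro group proves sensitive to substitution, which the step between the two singly substituted rings could not reveal: adding one fluoro gives a 14-fold higher number from compound 2 to compound 3 (1.14 log units; beyond the scatter) and so turns the binding result sharply weaker. Set against the 3-methylphenyl ring, 3,5-difluorophenyl gives a 17-fold higher number from compound 1 to compound 3 (1.22 log units; beyond the scatter) and is likewise far weaker, so among these three compounds, the large loss appears only with the ring that carries two substituents. Nothing shown here offers an explanation for this loss.

As far as these compounds go, it remains open whether the loss belongs to fluoro specifically or would also appear with another group at this position, such as chloro, methyl or methoxy. Whether a second fluoro elsewhere on the ring would behave the same way also stays unanswered.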